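Replacing Dimethylamino with Methyl on a Carbonyl Carbon

The compounds below may be only part of what the source reports. "The series", "measured", "known", "first", "only" and "open" are said of these compounds alone.

Compound 1, `CC(=O)Cn1nnnc1Cc1ccc(-c2ccccc2)cc1`: > 10000 nM
Compound 2, `CN(C)C(=O)Cn1nnc(CNC(=O)c2ccc(-c3ccccc3)cc2)n1`: > 10000 nM
Compound 3, `CC(=O)Cn1nnnc1CNC(=O)c1ccc(-c2ccccc2)cc1`: > 10000 nM

All three measured compounds were tested in an assay on isolated protein (COS cells) for inhibition of diacylglycerol lipase-alpha (Homo sapiens); on this read-out lower numbers stand for stronger inhibition and higher numbers for weaker inhibition. For compound 1 the result > 10000 nM is a limit of the assay, not a number. For compound 2 the result > 10000 nM is likewise a limit. For compound 3 the result > 10000 nM is a limit as well. So compound 2 stands where every measured value stands: at the limit, as summarised in the limit of > 10000 nM in this assay, at which 3 of the 3 values shown sit. Among the measured compounds shown here, no two measured compounds differ in only one place, so no measured step is available to size.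

The unmeasured compound 4, `CC(=O)Cn1nnc(CNC(=O)c2ccc(-c3ccccc3)cc2)n1`, differs from compound 2 in one place: methyl in place of dimethylamino on a carbonyl carbon. Compound 3 already carries the acetyl group on a core of its own and also sits at the limit, which offers no sign that this group alone brings measurable inhibition.

With nothing measured leaving the limit, the step that the limit leaves unreadable from compound 2 to compound 4 is expected to be none beyond the scatter. Compound 4 is therefore expected to give about 15000 nM, within 5000 nM to 50000 nM, most likely again reported only as a limit.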

Compound 4, half-maximal inhibitory concentration: > 10000 nM
Compound 4 ended at the assay's limit; the forecaster's own chance of this, stated with the estimate: 85%; the middle value is on the limit's open side.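

In this assay compound 4 gives > 10000 nM and this is a limit of the assay, not a number. Compound 2 also sits at a limit, so the step from compound 2 to compound 4 cannot be read: the limit of > 10000 nM in this assay, at which 4 of the 4 values shown sit.

The compounds shown leave open how far dimethylcarbamoyl to acetyl would move a value that lies inside the assay's measurable range.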